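A few compounds are considered here, and "the series" means these few. Any claim that something is new, unique, unknown or untested is made for them only; others in the source may bear on it.

Compound 2 `COC(CC(=O)O)c1ccc(OCc2cccc(-c3c(C)cccc3C)c2)s1` carries 2-carboxy-1-methoxyethyl on the core shared with compound 1 `Cc1cccc(C)c1-c1cccc(COc2ccc(CC3SC(=O)NC3=O)s2)c1`. In a functional assay on cells for agonist activity at Free fatty acid receptor 1 (Homo sapiens), read by calcium flux (a higher number here means that more compound is needed for the effect, a lower number that less compound is needed), compound 2 gives 210 nM, the higher of the two numbers in hand. In this assay compound 1 gives 82 nM. Going by the values given here, the single measured step, a 2.6-fold higher number from compound 1 to compound 2 (0.41 log units; beyond the scatter), swaps the acidic head group and leaves the methoxy untouched, so it does not speak to the change now in view. Compound 3 `CCOC(CC(=O)O)c1ccc(OCc2cccc(-c3c(C)cccc3C)c2)s1` differs from compound 2 by methyl in place of hydrogen on a saturated chain carbon bound to an oxygen on a saturated carbon, read one bond further out as methoxy to ethoxy. Among the compounds with values here, no measured pair shows the effect of such a change, and a single added methyl on a saturated chain carbon gives no ground to expect a step beyond the scatter in this assay. The step expected here is therefore a 1.1-fold lower number from compound 2 to compound 3 (0.02 log units; within the scatter). For compound 3 the expected value in this assay is 200 nM, with a range from 90 nM to 450 nM.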

Compound 3, half-maximal effective concentration: 57 nM
Compound 3: middle estimate off by 3.5-fold (0.55 log units), on the high side; measured number outside the range, below it.
By their numbers in this assay, from the lowest: compounds 3 and 1 (each within the scatter of the next); then compound 2.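

Methoxy to ethoxy, the first measured change at this position, is not neutral in this assay: the added methyl gives a 3.7-fold lower number from compound 2 to compound 3 (0.57 log units; beyond the scatter). With ethoxy in place, the gap seen between the two head groups closes, with 2-carboxy-1-ethoxyethyl against (2,4-dioxo-1,3-thiazolidin-5-yl)methyl giving a 1.4-fold lower number from compound 1 to compound 3 (0.16 log units; within the scatter), so the outcome of that swap depends on the group carried on the saturated chain carbon in these compounds. Nothing available accounts for the size of the methyl step.

The compounds shown leave open whether a longer chain such as propoxy or a branched group such as isopropoxy would lower the number further or reverse the step. They also leave open how a hydroxyl or an amine on the same carbon would read in this assay.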